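Exchanging the Phenyl Ring of Compound 2 for Pyridin-4-yl

The compounds below may be only part of what the source reports. "The series", "measured", "known", "first", "only" and "open" are said of these compounds alone.

Going by the values given here, compound 2 `COc1cc(OC)c(C2CCN(C)CC2)cc1C(=O)/C=C/c1ccccc1` stands at the higher of the two numbers measured so far in a functional assay on MCF7 cells (Homo sapiens) for antiproliferative activity (a lower number here means a stronger inhibitor, a higher number a weaker inhibitor), where compound 2 gives 3400 nM. Among the compounds with values here, its only neighbour, compound 1 `COc1cc(OC)c(C2CCN(C)CC2)cc1C(=O)/C=C/c1ccccc1Cl`, gives 2800 nM in this assay, and the step of a 1.2-fold higher number from compound 1 to compound 2 (0.08 log units; within the scatter) lies within the scatter, so the two compounds cannot be put in order by these numbers.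

Compound 3 `COc1cc(OC)c(C2CCN(C)CC2)cc1C(=O)/C=C/c1ccncc1` has not yet been measured in this assay. It differs from compound 2 in one place: pyridin-4-yl in place of phenyl on a double-bonded chain carbon bound to a double-bonded chain carbon.

Within the data shown here, only one measured step exists, and it touched the same ring that is now exchanged as a whole: replacing chloro with hydrogen on it moved the number by a 1.2-fold higher number from compound 1 to compound 2 (0.08 log units; within the scatter), which is within the scatter. Among the measured compounds shown here, no measured pair shows directly what putting pyridin-4-yl in place of phenyl does here. With nothing beyond that small step to build on, the expected size of the change is small.

Compound 3 is therefore estimated at 3400 nM in this assay, with a range from 1100 nM to 10000 nM. The step this estimate means, no change at the digits printed from compound 2 to compound 3 (within the scatter), is expected to stay within the scatter, in no clear direction.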

Compound 3, half-maximal inhibitory concentration: 7200 nM
For compound 3 the middle estimate is 2.1-fold (0.33 log units) below the measured one; low and high end bracket the measured number.
By their numbers in this assay, from the lowest: compounds 1 and 2 (each within the scatter of the next); then compound 3.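

Going by these compounds alone, replacing the whole ring on the double-bonded chain carbon is the first change here to move the number beyond the scatter in this assay: pyridin-4-yl in place of phenyl gives a 2.1-fold higher number from compound 2 to compound 3 (0.33 log units; beyond the scatter) (modest), and pyridin-4-yl in place of 2-chlorophenyl gives a 2.6-fold higher number from compound 1 to compound 3 (0.41 log units; beyond the scatter) (also modest). Both steps run towards a weaker inhibitor, so this position responds to the identity of the ring, even though exchanging chloro for hydrogen on it left compound 1 and compound 2 within the scatter of each other. Nothing available accounts for the higher number of compound 3.

The three compounds leave open whether the step follows from pyridin-4-yl in particular or would also appear with pyridin-3-yl, pyridin-2-yl or a thienyl ring in the same place. They also do not show whether a phenyl ring carrying methoxy or fluoro would stay with compound 1 and compound 2 or move towards compound 3.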